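The compounds below may be only part of what the source reports. "The series", "measured", "known", "first", "only" and "open" are said of these compounds alone.

Within the data shown here, compound 2 `ClCc1ccccc1Cn1cnc2ncnc(Cl)c21` stands at the weak end of the three compounds measured so far: in a functional assay on SNB-75 cells (Homo sapiens) for cytotoxicity, read by sulforhodamine B assay, with a stated time of 48 h (on this read-out lower numbers stand for stronger inhibition of growth and higher numbers for weaker inhibition of growth), compound 2 gives 11200 nM, the highest number of the set. Compound 3 `Nc1nc(Cl)c2ncn(Cc3cccc(CCl)c3)c2n1` is its nearest neighbour; in this assay compound 3 gives 5750 nM, a gap that lies within the scatter, so the two cannot be ordered. Compound 1 `ClCc1ccccc1Cn1cnc2c(Cl)nc(Cl)nc21` is the furthest away, giving 1540 nM in this assay, a difference that lies beyond the scatter.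

Compound 4 `ClCc1ccccc1Cn1cnc2nc(Cl)nc(Cl)c21` has not yet been measured. It differs from compound 2 by a single change: chloro in place of hydrogen on an aromatic carbon. Among the measured compounds shown here, no measured pair shows exactly this change, so the direction and size of the step can only be guessed. Compound 1 also carries two chloro groups on the shared core and gives a markedly lower number than compound 2, which offers a loose hint that a second chloro group may help. On that basis compound 4 is expected to fall below compound 2, with an estimated step of a 2.5-fold lower number from compound 2 to compound 4 (0.40 log units; beyond the scatter) in this assay. The estimate for compound 4 in this assay is 4500 nM, with a range from 1500 nM to 13000 nM.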

Compound 4, concentration for 50% growth inhibition: 1900 nM
Estimate against measurement, compound 4: 2.4-fold (0.37 log units) above; low and high end bracket the measured number.
By their numbers in this assay, from the lowest: compounds 1 and 4 (each within the scatter of the next); then compounds 3 and 2 (each within the scatter of the next).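

In this assay, the change of chloro in place of hydrogen gives the first step read between two compounds that differ in one place: a 5.9-fold lower number from compound 2 to compound 4 (0.77 log units; beyond the scatter). It shows that, on this core, a chloro group on the aromatic carbon between two ring nitrogen atoms goes with a lower number, by a margin that clears the scatter, when a chloro group is already present meta to that carbon. Nothing available explains why this chloro group has this effect.

Going by these compounds, whether a methoxy group or a fluoro group on the same carbon would also lower the number remains open, as does whether a bromo group would match chloro there. Also open, on these data alone, is whether the step would hold if the existing chloro group were replaced by a methoxy group.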